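Trading a methoxyphenyl arm for bromine on the shared core

The source may report more compounds than this note shows. Statements on the series, on what has been measured and on what is new or still open speak of the compounds shown alone.

Measured compounds:
compound 1 `CCOc1ccccc1-c1ccc(-c2nc3cnccc3c(N[C@H](CC)C(=O)N(C)C)c2C#N)cc1`: 3.7
compound 2 `CCOc1ccccc1-c1ccc(-c2nc3cnccc3c(C[C@H](C)C(=O)O)c2C#N)cc1`: 2.2
compound 3 `CC[C@@H](Nc1c(C#N)c(-c2ccc(-c3ccc(OC)cc3)cc2)nc2cnccc12)C(N)=O`: 2.7

In a physicochemical assay for lipophilicity, read by HPLC, at pH 7.5 (a higher number here means a more lipophilic compound, a lower number a more polar compound), compound 1 gives 3.7, compound 2 gives 2.2 and compound 3 gives 2.7. Compound 3 therefore holds the second highest of the three numbers: its nearest neighbour is compound 2, whose value is lower by an amount beyond the scatter, and its furthest is compound 1, whose value is higher by a larger amount, again beyond the scatter.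

Compound 4 `CC[C@@H](Nc1c(C#N)c(-c2ccc(Br)cc2)nc2cnccc12)C(N)=O` has not yet been measured. It differs from compound 3 in one place: bromo in place of 4-methoxyphenyl on an aromatic carbon.

Going by the values given here, the only measured step, a number 1.50 log units lower from compound 1 to compound 2 (beyond the scatter), concerns a different substituent on a different aromatic carbon of the shared core, so it does not bear directly on this change. What remains is the structural change itself: a group of eight heavy atoms with a carbon ring and one hydrogen-bond acceptor leaves, and a single bromine enters. A step downward in this assay, beyond the scatter, is therefore expected, a number 0.90 log units lower from compound 3 to compound 4 (beyond the scatter). Compound 4 is estimated to give 1.8, with a range from 1.2 to 2.4.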

Compound 4, distribution coefficient: 2.2
The estimate for compound 4 lay 0.40 log units below the measured number; the measured number falls inside the stated range.
By their numbers in this assay, from the lowest: compounds 2 and 4 (each within the scatter of the next); then compound 3; then compound 1.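

In this assay, going by these compounds alone, putting bromo in place of 4-methoxyphenyl, on an aromatic carbon para to a large group, gives a number 0.50 log units lower from compound 3 to compound 4 (beyond the scatter), which shows that this position also registers a change, something the earlier compounds could not show because their one step lay at a different aromatic carbon. The new step is modest, although the group that leaves has 8 heavy atoms, a six-membered aromatic ring of carbon only and a hydrogen-bond acceptor, while only a single bromine enters; the step at the other position, a number 1.50 log units lower from compound 1 to compound 2 (beyond the scatter), is large. Nothing available accounts for the size of the new step.

On these data alone, because the ring, the methoxy group and the bromine all change in this one exchange, their shares in the step remain open, and a plain phenyl, a chloro group or a lone hydrogen at this place would be needed to separate them. Also open, as far as these compounds go, is whether the step would keep its size on a core carrying a carboxylic acid chain, such as the 2-carboxypropyl group, at the other position.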